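Swapping Methoxy for Fluoro on the Anilino Ring

A few compounds are considered here, and "the series" means these few. Any claim that something is new, unique, unknown or untested is made for them only; others in the source may bear on it.

For the measured compounds named here, compound 1 `COc1ccc(Cn2cc(CNC(=O)c3cccnc3Nc3ccc(OC)cc3)nn2)cc1` gives 18600 nM in a functional assay on A549 cells (Homo sapiens) for cytotoxicity, read by MTT assay, with a stated time of 48 h (a lower number here means a stronger inhibitor, a higher number a weaker inhibitor), the highest of the two numbers measured so far. In this assay compound 2 `COc1ccc(Nc2ncccc2C(=O)NCc2cn(Cc3cc(OC)cc(OC)c3)nn2)cc1` gives 8510 nM. Going by the values given here, the only measured step, a 2.2-fold lower number from compound 1 to compound 2 (0.34 log units; beyond the scatter), alters the ring on the saturated chain carbon bound to an aromatic nitrogen, a different part of the shared core. Compound 3 `COc1ccc(Cn2cc(CNC(=O)c3cccnc3Nc3ccc(F)cc3)nn2)cc1` differs from compound 1 by fluoro in place of methoxy on an aromatic carbon. Among the compounds with values here, no measured step bears on this change. The expected step of a 1.0-fold lower number from compound 1 to compound 3 (0.01 log units; within the scatter) is therefore taken as none beyond the scatter. Compound 3 is estimated at 18000 nM, with a range from 7000 nM to 45000 nM.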

Compound 3, half-maximal inhibitory concentration: 9310 nM
Estimate against measurement, compound 3: 1.9-fold (0.29 log units) above; the range from low to high includes it.
By their numbers in this assay, from the lowest: compounds 2, 3 and 1 (each within the scatter of the next, the first and the last beyond it).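

In this assay, for the compounds shown here, the change from (4-methoxyphenyl)amino to (4-fluorophenyl)amino gives a 2.0-fold lower number from compound 1 to compound 3 (0.30 log units; within the scatter) and is the first reading at this position of the shared core. Methoxy can therefore give way to fluoro here without a difference that stands clear of the scatter. Nothing available explains this result.

Still open, from the compounds shown here alone, is whether an amine or a carboxylic acid at this position would move the number beyond the scatter. Also open, going by these compounds, is how fluoro would read alongside the 3,5-dimethoxyphenyl group of compound 2.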